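Stepping back from pentafluorophenyl to 2-fluorophenyl

The compounds below may be only part of what the source reports. "The series", "measured", "known", "first", "only" and "open" are said of these compounds alone.

In a functional assay on Caco-2 cells (Homo sapiens) for inhibition, read by MTT assay, with a stated time of 48 h, tested at 10 uM (on this read-out higher numbers stand for more inhibition of growth at the one concentration tested and lower numbers for less inhibition of growth), compound 1 (`CN1CC[C@H](c2c(O)cc(O)c3c(=O)cc(/C=C/c4ccccc4)oc23)[C@H](O)C1`) gives 72% and compound 2 (`CN1CC[C@H](c2c(O)cc(O)c3c(=O)cc(/C=C/c4c(F)c(F)c(F)c(F)c4F)oc23)[C@H](O)C1`) gives 59% as the lower of the two numbers. Compound 3 (`CN1CC[C@H](c2c(O)cc(O)c3c(=O)cc(/C=C/c4ccccc4F)oc23)[C@H](O)C1`) differs from compound 2 by 2-fluorophenyl in place of 2,3,4,5,6-pentafluorophenyl on a double-bonded chain carbon bound to a double-bonded chain carbon with 2-fluorophenyl in place of 2,3,4,5,6-pentafluorophenyl. Among the compounds with values here, only one measured step bears on this change: a number 13 percentage points lower from compound 1 to compound 2 (beyond the scatter) on replacing phenyl with 2,3,4,5,6-pentafluorophenyl. From that step a partial return upward is expected. The expected move in this assay is a number 7 percentage points higher from compound 2 to compound 3 (within the scatter) and is smaller than that step. Compound 3 is estimated at 66% with a range from 54% to 78% as the expected span.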

Compound 3, percent growth inhibition at one concentration: 68%
Beside the measured number, compound 3's estimate is 2 percentage points below it; the measured number falls inside the stated range.
By their numbers in this assay, from the lowest: compounds 2, 3 and 1 (each within the scatter of the next, the first and the last beyond it).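

With 2-fluorophenyl in place of phenyl there is a number 4 percentage points lower from compound 1 to compound 3 (within the scatter) in this assay, and with 2-fluorophenyl in place of 2,3,4,5,6-pentafluorophenyl there is a number 9 percentage points higher from compound 2 to compound 3 (within the scatter) on the same read-out. Compound 3 thus lies within the scatter of both compound 1 and compound 2, and among these steps only the change from phenyl to 2,3,4,5,6-pentafluorophenyl stands beyond the scatter. Nothing available here accounts for these numbers.

Open, from the compounds shown here alone, is whether the numbers follow the count of fluorines on this ring, and how a chloro, a methoxy or an amine would read in place of the fluoro.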